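A few compounds are considered here, and "the series" means these few. Any claim that something is new, unique, unknown or untested is made for them only; others in the source may bear on it.

In a functional assay on BT-474 cells (Homo sapiens) for inhibition, read by fluorescence, with a stated time of 72 h (on this read-out higher numbers stand for weaker inhibition of growth and lower numbers for stronger inhibition of growth), the measured compounds are:

- compound 1 `CC(C)CCn1cnc2c(Nc3ccc(Cl)cc3)nc(N[C@H]3CC[C@H](N)CC3)nc21`: 5100 nM
- compound 2 `CCCCCCn1cnc2c(Nc3ccc(Cl)cc3)nc(N[C@H]3CC[C@H](N)CC3)nc21`: 5500 nM
- compound 3 `CCCCn1cnc2c(Nc3ccc(Cl)cc3)nc(N[C@H]3CC[C@H](N)CC3)nc21`: 7300 nM

Compound 1 stands level with the other two, as a 1.1-fold higher number from compound 1 to compound 2 (0.03 log units; within the scatter) and a 1.4-fold higher number from compound 1 to compound 3 (0.16 log units; within the scatter) both lie within the scatter, as does a 1.3-fold higher number from compound 2 to compound 3 (0.12 log units; within the scatter). Compound 4 `CC(C)CCn1cnc2c(Nc3cccc(O)c3)nc(N[C@H]3CC[C@H](N)CC3)nc21` keeps the saturated chain of compound 1 and carries 3-hydroxyphenyl in place of 4-chlorophenyl on a nitrogen on an aromatic ring. The measured steps alter only the chain, so none tests this change. They give no direction, and no step beyond the scatter is expected, though with wide uncertainty. The estimated step is a 1.0-fold lower number from compound 1 to compound 4 (0.01 log units; within the scatter). The estimate for compound 4 is 5000 nM, with an expected range of 1000 nM to 20000 nM.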

Compound 4, concentration for 50% growth inhibition: 14700 nM
The estimate for compound 4 lay 2.9-fold (0.47 log units) below the measured number; the range from low to high includes it.
By their numbers in this assay, from the lowest: compounds 1, 2, 3 and 4 (each within the scatter of the next, the first and the last beyond it).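

In this assay, the change on the nitrogen produced a step beyond the scatter, which none of the chain changes among compound 1, compound 2 and compound 3 had done: 3-hydroxyphenyl in place of 4-chlorophenyl gave a 2.9-fold higher number from compound 1 to compound 4 (0.46 log units; beyond the scatter). This position therefore affects growth inhibition, modestly, and here the change weakened it. No available evidence accounts for this step.

The compounds shown leave open whether the step follows from losing the chlorine, gaining the hydroxyl or moving the substituent on the ring. 3-Chlorophenyl and 4-hydroxyphenyl at this position would separate these possibilities.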